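Amide variation on the sulfonylpiperazine series: next step

The source may hold more compounds than are shown below. What is called first, only, known or untested is meant among the compounds shown, and "the series" means these compounds.

Measured so far in an ADME assay on HepG2 cells (Homo sapiens) for inhibition, with a stated time of 48 h; a lower number here means that less compound is needed, a higher number that more compound is needed for the effect:
- compound 1, `CCN(CC)C(=O)C(C)N1CCN(S(=O)(=O)c2ccc(C(C)(C)C)cc2)CC1`: > 40000 nM, a limit of the assay rather than a number.
- compound 2, `CC(C(=O)N1CCCCCC1)N1CCN(S(=O)(=O)c2ccc(C(C)(C)C)cc2)CC1`: > 40000 nM, again a limit.
- compound 3, `CC(C(=O)N1CCC(C)(C)CC1)N1CCN(S(=O)(=O)c2ccc(C(C)(C)C)cc2)CC1`: > 40000 nM, again a limit.

Compound 2 therefore stands only at a limit in this assay, and the two further values shown are limits as well, so that (the limit of > 40000 nM in this assay, at which 3 of the 3 values shown sit). The three measured steps, a step that the two limits leave unreadable from compound 1 to compound 2, a step that the two limits leave unreadable from compound 1 to compound 3 and a step that the two limits leave unreadable from compound 2 to compound 3, are all between limits and give no readable size in either direction. Changing the amine on the carbonyl carbon, from diethylamino through azepan-1-yl to 4,4-dimethylpiperidin-1-yl, has so far left every compound at the limit.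

Compound 4, `CC(C(=O)N1CCc2ccccc2C1C)N1CCN(S(=O)(=O)c2ccc(C(C)(C)C)cc2)CC1`, is not yet measured. Its change from compound 2: 1-methyl-1,2,3,4-tetrahydroisoquinolin-2-yl in place of azepan-1-yl on a carbonyl carbon. For the measured compounds named here, the steps that bear on it, those from compound 1 to compound 2, from compound 1 to compound 3 and from compound 2 to compound 3, are all unreadable, so no size or direction beyond the scatter can be expected from them. The most likely outcome is that compound 4 again sits at the limit. Compound 4 is accordingly estimated in this assay at 45000 nM, with a range from 12000 nM to 150000 nM. The step this estimate means, a step that the limit leaves unreadable from compound 2 to compound 4, is expected to be within the scatter and very likely unreadable.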

Compound 4, half-maximal effective concentration: 28000 nM
Compound 4: the middle estimate sits 1.6-fold (0.21 log units) above what was measured; measured number inside the range.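

In this assay, for the compounds shown here, compound 4 is the first compound with a change on this carbonyl carbon to give a number rather than a limit, while the other amines stay at the limit: the limit of > 40000 nM in this assay, at which 3 of the 4 values shown sit. The new comparisons are an at least 1.4-fold lower number from compound 2 to compound 4 (0.15 log units; that floor lies within the scatter), an at least 1.4-fold lower number from compound 3 to compound 4 (0.15 log units; that floor lies within the scatter) and an at least 1.4-fold lower number from compound 1 to compound 4 (0.15 log units; that floor lies within the scatter). Each is only a floor, so the true size of all three steps stays unread, and the one firm gain is a single number for this series, carried by the 1-methyl-1,2,3,4-tetrahydroisoquinolin-2-yl amide with its six-membered aromatic ring of carbon only.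

The ring and the methyl group enter together in compound 4, so the compounds shown leave open which of the two goes with the measurable number, and a 1,2,3,4-tetrahydroisoquinolin-2-yl amide without the methyl group would separate them. Also open, from the compounds shown here alone, is whether a simpler amine carrying an aromatic ring, such as N-methylbenzylamino, would likewise give a number in this assay or stay at the limit.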